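The compounds below may be only part of what the source reports. "The series", "measured", "known", "first", "only" and "open" are said of these compounds alone.

Compound 1 `O=c1cc(-c2ccccc2)oc2cc(N3COc4c(Br)cccc4C3)ccc12`: 19.5%
Compound 2 `O=c1cc(-c2ccccc2)oc2cc(N3COc4c(Br)cc(Br)cc4C3)ccc12`: 26.5%

In a functional assay on MCF7 cells (Homo sapiens) for inhibition, read by MTT assay, with a stated time of 48 h, tested at 60 ug/mL (on this read-out lower numbers stand for less inhibition of growth and higher numbers for more inhibition of growth at the one concentration tested), compound 1 gives 19.5%, the lower of the two measured values. For the measured compounds named here, the only measured step, a number 7 percentage points higher from compound 1 to compound 2 (within the scatter), stays within the scatter. Compound 3 `O=c1cc(-c2ccccc2)oc2cc(N3COc4ccccc4C3)ccc12` differs from compound 1 by hydrogen in place of bromo on an aromatic carbon. Going by the values given here, that change is the mirror of the one measured step, so it is the only guide, and it showed no movement beyond the scatter; the expected step of a number 5.5 percentage points lower from compound 1 to compound 3 (within the scatter) is therefore none beyond the scatter. Compound 3 is estimated at 14%, with a range from 3% to 28%.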

Compound 3, percent growth inhibition at one concentration: 19.3%
Beside the measured number, compound 3's estimate is 5.3 percentage points below it; the measured number falls inside the stated range.
By their numbers in this assay, from the lowest: compounds 3, 1 and 2 (each within the scatter of the next).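

In this assay, the step of a number 0.2 percentage points lower from compound 1 to compound 3 (within the scatter) means that bromo and hydrogen cannot be told apart on this aromatic carbon. The bromo therefore shows no need to be at this position for the growth inhibition seen here, and the core of compound 3 keeps its value without any bromo. Nothing shown gives a reason for this result. Still open, going by these compounds, is whether a group of a different kind on this carbon, such as an amine or a carboxylic acid, would move the number beyond the scatter.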